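The source may report more compounds than this note shows. Statements on the series, on what has been measured and on what is new or still open speak of the compounds shown alone.

In a functional assay on HL60/MX2 cells (Homo sapiens) for antiproliferative activity, read by MTT assay, with a stated time of 48 h (a lower number here means a stronger inhibitor, a higher number a weaker inhibitor), compound 1 `CN(C)CCCCn1c(N)c(-c2nc3ccccc3o2)c2nc(C#N)c(C#N)nc21` gives 960 nM, while compound 2 `CCN(CC)CCCCn1c(N)c(-c2nc3ccccc3o2)c2nc(C#N)c(C#N)nc21` gives 1720 nM. The change separating them, (diethylamino in place of dimethylamino on a saturated chain carbon, four bonds along the chain from an aromatic nitrogen), produced a 1.8-fold higher number from compound 1 to compound 2 (0.25 log units; within the scatter). Compound 3 `CN(C)CCn1c(N)c(-c2nc3ccccc3n2C)c2nc(C#N)c(C#N)nc21` rests on a different core; the difference between its core and the core of compound 1 is not broken down here. In this assay compound 3 gives 4680 nM, the highest number among the three measured compounds. Compound 4 `CCN(CC)CCn1c(N)c(-c2nc3ccccc3n2C)c2nc(C#N)c(C#N)nc21` carries the same kind of change relative to compound 3, (diethylamino in place of dimethylamino on a saturated chain carbon, two bonds along the chain from an aromatic nitrogen), though the place differs: here the change sits two bonds along the chain from an aromatic nitrogen rather than four. Because the earlier step of a 1.8-fold higher number from compound 1 to compound 2 (0.25 log units; within the scatter) remained within the scatter, a similarly small step is expected here, a 1.6-fold higher number from compound 3 to compound 4 (0.20 log units; within the scatter). Compound 4 is therefore estimated at 7500 nM in this assay, most likely between 3000 nM and 18000 nM.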

Compound 4, half-maximal inhibitory concentration: 3250 nM
For compound 4 the middle estimate is 2.3-fold (0.36 log units) above the measured one; the range from low to high includes it.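

In this assay, putting diethylamino in place of dimethylamino gave a 1.4-fold lower number from compound 3 to compound 4 (0.16 log units; within the scatter), so on this second core the step again stayed within the scatter. Set side by side, the two steps do not differ beyond what repeated measurement allows: the same change on two cores in this assay, a 1.8-fold higher number (0.25 log units; within the scatter) from compound 1 to compound 2 and a 1.4-fold lower number (0.16 log units; within the scatter) from compound 3 to compound 4, 2.6-fold (0.41 log units) apart, within the scatter of two such steps. This suggests that the change carried over between these two cores as a small step, even with the place differing along the chain, but it shows no direction for the change and says nothing about any other core.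

The compounds shown leave open how a dipropylamino group or a primary amine would behave at the end of the chain. They also leave open whether a longer chain on either core would keep the step this small.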